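Cytotoxicity After Exchanging a Chain for a Fluorophenylcarbonyl Group

The source may hold more compounds than are shown below. What is called first, only, known or untested is meant among the compounds shown, and "the series" means these compounds.

Compound 1 `CC(C)(C)OC(=O)Nc1ncc(C(Oc2ccc(OCc3ccccc3)cc2)c2ccc(Cl)cc2)s1` and compound 2 `CCOC(=O)CCCNc1ncc(C(Oc2ccc3cc(Br)ccc3c2)c2ccc(Cl)cc2)s1` were both examined in an ADME assay on HepG2 2.2.15 cells (Homo sapiens) for cytotoxicity; on this read-out higher numbers stand for lower toxicity in this test and lower numbers for higher toxicity in this test. For compound 1 the result is a limit of the assay, > 50000 nM. This read-out is thus bounded at the limit of > 50000 nM in this assay, at which 1 of the 2 values shown sits. Compound 2 is recorded in this assay only as "not toxic" (no number reported), a description rather than a number, so no figure places it against compound 1. Compound 3 `O=C(Nc1ncc(C(Oc2ccc3cc(Br)ccc3c2)c2ccc(Cl)cc2)s1)c1ccc(F)cc1` differs from compound 2 by (4-fluorophenyl)carbonyl in place of 3-(ethoxycarbonyl)propyl on a nitrogen on an aromatic ring. For the measured compounds named here, no measured pair shows this change, and in this assay no shift beyond the scatter is expected. Compound 3 is estimated at 45000 nM, between 12000 nM and 100000 nM.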

Compound 3, half-maximal cytotoxic concentration: "not toxic" (no number reported)
Nothing numeric was reported for compound 3; there is nothing to compare the estimate with.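

Compound 2 and compound 3 are each recorded in this assay only as "not toxic", so no step can be read between them. On these data alone, whether (4-fluorophenyl)carbonyl in place of 3-(ethoxycarbonyl)propyl shifts the cytotoxic concentration at all remains open.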